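The compounds below may be only part of what the source reports. "The series", "measured", "known", "first", "only" and "open" are said of these compounds alone.

Compound 1 `COc1cc(-c2nnc(SCC(=O)c3ccc(Cl)cc3)n2N)cc(OC)c1OC` serves as the reference point of this series. For the measured compounds named here, in a functional assay on HeLa cells (Homo sapiens) for antiproliferative activity, read by MTT assay, with a stated time of 48 h (a higher number here means a weaker inhibitor, a lower number a stronger inhibitor), compound 1 gives 13100 nM, one of only two numbers recorded; the other belongs to compound 2 `COc1ccc(C(=O)CSc2nnc(-c3cc(OC)c(OC)c(OC)c3)n2N)cc1`, which gives 17400 nM, a gap that is a 1.3-fold higher number from compound 1 to compound 2 (0.12 log units; within the scatter). Compound 3 `COc1cc(-c2nnc(SCC(=O)Nc3ccccc3C)n2N)cc(OC)c1OC` reaches only a limit of the assay in this assay, at > 100000 nM. Two steps that replace the aryl group on the carbonyl carbon by an arylamino group are on hand, an at least 7.6-fold higher number from compound 1 to compound 3 (0.88 log units; beyond the scatter) and an at least 5.7-fold higher number from compound 2 to compound 3 (0.75 log units; beyond the scatter), both at least modest. The relevant evidence is the limit of > 100000 nM in this assay, at which 1 of the 3 values shown sits.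

Compound 4 `COc1cc(-c2nnc(SCC(=O)NCc3ccc(Cl)cc3)n2N)cc(OC)c1OC` differs from compound 1 as follows: (4-chlorobenzyl)amino in place of 4-chlorophenyl on a carbonyl carbon. The change again turns the ketone into an amide, so the steps to compound 3 bear on it, although a (4-chlorobenzyl)amino group is not the (2-methylphenyl)amino group of compound 3, and the 4-chlorophenyl ring of compound 1 is retained within the entering group. A step towards a higher number, beyond the scatter, is therefore expected in this assay, probably smaller than the steps to compound 3 but with a fair chance of ending at the limit. The expected step is a 4.6-fold higher number from compound 1 to compound 4 (0.66 log units; beyond the scatter). For compound 4 the estimate is 60000 nM, within 20000 nM to 200000 nM.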

Compound 4, half-maximal inhibitory concentration: > 100000 nM
Compound 4 ended at the assay's limit; the forecaster's own chance of this, stated with the estimate: 50%; middle value at least 1.6-fold (0.22 log units) away from the limit.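

In this assay compound 4 gives > 100000 nM, which is a limit of the assay and not a number. Keeping the 4-chlorophenyl ring within a (4-chlorobenzyl)amino group on the carbonyl carbon does not preserve a measurable number, with an at least 7.6-fold higher number from compound 1 to compound 4 (0.88 log units; beyond the scatter) and an at least 5.7-fold higher number from compound 2 to compound 4 (0.75 log units; beyond the scatter), so the loss on replacing the aryl ketone by an amide is no longer seen with the (2-methylphenyl)amino group of compound 3 alone. The step between 4-chlorobenzyl and 2-methylphenyl on the amide-type nitrogen cannot be read, and compound 3 and compound 4 cannot be ranked, as both stand at the same limit: the limit of > 100000 nM in this assay, at which 2 of the 4 values shown sit.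

Still open, on these data alone, is whether any amide in this position gives a measurable number, for example one carrying a morpholin-4-yl group, which has no amide hydrogen. Also open, as far as these compounds go, is whether the ketone series gives a step beyond the scatter with a different group in place of chloro or methoxy on the aromatic carbon, such as trifluoromethyl or a carboxylic acid.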